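Trimming a tert-butyl group on a receptor blocker

The source may report more compounds than this note shows. Statements on the series, on what has been measured and on what is new or still open speak of the compounds shown alone.

Of the compounds shown here, two that bind the same receptor have been measured so far. Compound 1 `CCCCN(CC)c1cc(C)nc2c1NC(=O)CN2c1ccc(C(C)(C)C)cc1Br` gives 4.2 nM in an assay on HEK-293T cells for displacement of a labelled ligand from corticotropin-releasing factor receptor 1 (Homo sapiens), read by scintillation counting, with a stated time of 2 h; on this read-out higher numbers stand for weaker inhibition and lower numbers for stronger inhibition. Compound 2 `CCCN(CCC)c1cc(C)nc2c1NC(=O)CN2c1ccc(C(C)C)cc1Br` gives 3.1 nM in this assay. Compound 1 has the higher of the two numbers, and its nearest neighbour is compound 2, but the gap between them lies within the scatter, so the two cannot be told apart on potency. Compound 3 `CCCCN(CC)c1cc(C)nc2c1NC(=O)CN2c1ccc(C)cc1Br` is a variant of compound 1 that has not yet been measured. The difference is methyl in place of tert-butyl on an aromatic carbon. Going by the values given here, no measured pair shows this change, so its effect can only be guessed from the fact that both measured compounds carry a branched group at that aromatic carbon and both give low numbers. A modest step toward higher numbers, meaning weaker inhibition, is expected, a 2.9-fold higher number from compound 1 to compound 3 (0.46 log units; beyond the scatter). Compound 3 is therefore expected to give about 12 nM in this assay, with a likely range from 4 nM to 40 nM.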

Compound 3, inhibition constant: 4.4 nM
Estimate against measurement, compound 3: 2.7-fold (0.44 log units) above, within the range that was stated.
By their numbers in this assay, from the lowest: compounds 2, 1 and 3 (each within the scatter of the next).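

In this assay the step is a 1.0-fold higher number from compound 1 to compound 3 (0.02 log units; within the scatter), so tert-butyl and methyl cannot be told apart at this aromatic carbon, meta to the bromo group, when the rest of compound 1 stays the same. Both earlier compounds carried a branched group here, so they could not show whether branching at this carbon matters for the number; this pair shows that, on the core and side chain of compound 1, a branched group is not needed to keep a low number. The group can also go from 4 heavy atoms to 1 without a difference beyond the scatter, which means that the size of this substituent, across this span, does not separate the two compounds, and nothing shown here gives a reason for this result.

The compounds shown leave open whether a hydrogen, a methoxy group, an amine or a carboxylic acid at this carbon would also give a number close to these. They also leave open whether methyl and tert-butyl would remain indistinguishable with the two propyl chains of compound 2 on the amine.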